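Aryl swap on compound 3: notes toward compound 4

A few compounds are considered here, and "the series" means these few. Any claim that something is new, unique, unknown or untested is made for them only; others in the source may bear on it.

In a functional assay on MCF7 cells (Homo sapiens) for inhibition, read by sulforhodamine B assay, with a stated time of 48 h, tested at 50 uM (a lower number here means less inhibition of growth, a higher number more inhibition of growth at the concentration tested), compound 1 (`CCCOc1ccc([C@@H]2CC(=O)c3cc(CC=C(C)C)c(OC)cc3O2)cc1`) gives 60% and compound 2 (`COc1ccc([C@@H]2C/C(=N/O)c3cc(CC=C(C)C)c(OC)cc3O2)cc1`) gives 63%, two values within the scatter of each other. Compound 3 (`COc1ccc([C@@H]2C/C(=N/OCc3cn(-c4ccc(Cl)cc4C)nn3)c3cc(CC=C(C)C)c(OC)cc3O2)cc1`) gives 37%, the lowest of the three and beyond the scatter from both. Compound 4 (`COc1ccc([C@@H]2C/C(=N/OCc3cn(-c4cc(OC)c(OC)c(OC)c4)nn3)c3cc(CC=C(C)C)c(OC)cc3O2)cc1`) carries 3,4,5-trimethoxyphenyl in place of 4-chloro-2-methylphenyl on an aromatic nitrogen of a five-membered aromatic ring with 3 nitrogen (3,4,5-trimethoxyphenyl in place of 4-chloro-2-methylphenyl on an aromatic nitrogen). Among the measured compounds shown here, no measured pair shows this change in this assay, so the size of the step remains a judgement. A small upward step is expected (a number 8 percentage points higher from compound 3 to compound 4 (within the scatter)), probably not beyond the scatter. Compound 4 is estimated at 45%, with an expected range of 27% to 63%.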

Compound 4, percent growth inhibition at one concentration: 45%
Beside the measured number, compound 4's estimate shows no gap at the digits printed; low and high end bracket the measured number.
By their numbers in this assay, from the lowest: compounds 3 and 4 (each within the scatter of the next); then compounds 1 and 2 (each within the scatter of the next).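

Exchanging 4-chloro-2-methylphenyl for 3,4,5-trimethoxyphenyl on the aromatic nitrogen gives, in this assay, a number 8 percentage points higher from compound 3 to compound 4 (within the scatter). The two aryl groups, which differ in substitution and heavy-atom count, therefore cannot be told apart at this position in this read-out at the single concentration tested. No measurement at hand bears on the result.

On these data alone, whether an unsubstituted phenyl or a benzyl group on the same nitrogen would read differently remains open. So does the effect of an aryl group carrying an amine or a carboxylic acid.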